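Amide-nitrogen substituent variation on the shared core

The compounds below may be only part of what the source reports. "The series", "measured", "known", "first", "only" and "open" are said of these compounds alone.

Measured so far:
- Compound 1, `O=C(NN1CCOCC1)c1c(O)c2cccnc2n(-c2ccccc2)c1=O`, a functional assay on the whole organism for inhibition, with Rattus norvegicus as the target, read by cytopathic effect and paw edema, at a dose of 100 mg/kg by the oral route; on this read-out higher numbers stand for more inhibition at the one dose given (going by the name of the read-out) and lower numbers for less inhibition: -26.2%
- Compound 2, `Nc1ccc(NC(=O)c2c(O)c3cccnc3n(-c3ccccc3)c2=O)cc1`, in this assay: 0%

Among the compounds with values here, compound 2 stands highest of the two numbers; its nearest neighbour is compound 1, and the one step known, a number 26.2 percentage points higher from compound 1 to compound 2 (beyond the scatter), lies beyond the scatter. Compound 3, `O=C(Nc1nccs1)c1c(O)c2cccnc2n(-c2ccccc2)c1=O`, is not yet measured in this assay. It differs from compound 2 by 1,3-thiazol-2-yl in place of 4-aminophenyl on an amide-type nitrogen. Within the data shown here, no measured step replaces one aromatic ring on the amide-type nitrogen by another; the only step known exchanges morpholin-4-yl for 4-aminophenyl, so it bears on compound 3 only indirectly, as a sign that this position moves the read-out. With nothing closer to go on, compound 3 is expected to land near compound 2, so the estimated step is a number 5 percentage points higher from compound 2 to compound 3 (within the scatter), not beyond the scatter in either direction. The estimate for compound 3 is therefore 5%, within -20% to 30%.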

Compound 3, a percentage reported as inhibition, in the whole organism at one dose (the size of the read-out at that dose, not a potency): 2.5%
Compound 3: middle estimate off by 2.5 percentage points, on the high side, within the range that was stated.
By their numbers in this assay, from the lowest: compound 1; then compounds 2 and 3 (each within the scatter of the next).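

Putting 1,3-thiazol-2-yl in place of 4-aminophenyl on the amide-type nitrogen gives, in this assay, a number 2.5 percentage points higher from compound 2 to compound 3 (within the scatter), so a five-membered aromatic ring with 2 hetero atoms and a six-membered aromatic ring of carbon only read alike at this position. Set against morpholin-4-yl, 1,3-thiazol-2-yl gives a number 28.7 percentage points higher from compound 1 to compound 3 (beyond the scatter), so the gap first seen with 4-aminophenyl is not tied to that one group, though both steps rest on compound 1 alone. Nothing measured here accounts for either step.

Open, as far as these compounds go, is whether a plain phenyl, a pyridin-2-yl ring or a short alkyl chain on this nitrogen would read with compounds 2 and 3 or with compound 1. Also open, from the compounds shown here alone, is whether any group here gives clear inhibition at this dose.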